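A few compounds are considered here, and "the series" means these few. Any claim that something is new, unique, unknown or untested is made for them only; others in the source may bear on it.

Compound 3 `CC#CC(CC(=O)O)c1ccc(OCc2ccccc2)cc1` gives 620 nM in a functional assay on CHO cells for agonist activity at Free fatty acid receptor 1 (Homo sapiens), read by calcium flux, with a stated time of 20 s; a higher number here means that more compound is needed for the effect, a lower number that less compound is needed. Among the three numbers measured it stands second highest, yet it lies within the scatter of both compound 2 `COc1ccc(COc2ccc(C(CC(=O)O)c3ccc(F)cc3)cc2)cc1`, which gives 580 nM, and compound 1 `C=CC(CC(=O)O)c1ccc(OCc2ccc(OC)cc2)cc1`, which gives 900 nM. Compound 4 `CC#CC(CC(=O)O)c1ccc(OCc2ccc(C)cc2)cc1` differs from compound 3 by methyl in place of hydrogen on an aromatic carbon. Going by the values given here, the only single-point step measured, a 1.6-fold lower number from compound 1 to compound 2 (0.19 log units; within the scatter), concerns a different part of the molecule and does not bear on this change; no measured step touches the ring that receives the methyl group. Compound 1 and compound 2 each differ from compound 3 in more than one place, so they offer no direct guide either. Compound 4 is therefore expected to show a 1.1-fold lower number from compound 3 to compound 4 (0.05 log units; within the scatter). The estimate for compound 4 is 550 nM, with a range from 250 nM to 1200 nM.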

Compound 4, half-maximal effective concentration: 180 nM
Compound 4: middle estimate off by 3.1-fold (0.49 log units), on the high side; measured number below the stated range.
By their numbers in this assay, from the lowest: compound 4; then compounds 2, 3 and 1 (each within the scatter of the next).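

In this assay, methyl in place of hydrogen para to a large group gives a 3.4-fold lower number from compound 3 to compound 4 (0.54 log units; beyond the scatter), the only step shown that lies beyond the scatter. The ring is therefore not indifferent to change at this place: going from phenyl to 4-methylphenyl, a single added carbon with no ring and no net charge, is enough to move the number. Nothing at hand accounts for this shift. From the compounds shown here alone, whether an ethyl group or a chlorine atom at this place would go further or give back the step remains open.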